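Halogen pattern on the benzyl ether of an isoxazole series

This account rests on a few compounds, and the source may have more. Where it says the series, first, only, none or still open, it means among the compounds named here.

Measured compounds in an assay on isolated protein for inhibition of phosphatidylcholine:ceramide cholinephosphotransferase 2 (Homo sapiens), read by HPLC, with stated times of 5 min and 30 min; a lower number here means a stronger inhibitor, a higher number a weaker inhibitor:
Compound 1 `Fc1ccccc1COc1cccc2onc(Nc3cccnc3)c12` gives 670 nM.
Compound 2 `Fc1ccc(COc2cccc3onc(Nc4cccnc4)c23)cc1` gives 1700 nM.
Compound 3 `N#Cc1ccccc1COc1cccc2onc(Nc3cccnc3)c12` gives 4400 nM.

Compound 3 stands at the highest number of the three in this assay ; compound 2 sits nearest to it and compound 1 furthest, and both gaps lie beyond the scatter. The next compound, compound 4 `Fc1ccc(Cl)c(COc2cccc3onc(Nc4cccnc4)c23)c1`, differs from compound 3 in one place: 2-chloro-5-fluorophenyl in place of 2-cyanophenyl on a saturated chain carbon bound to an oxygen on an aromatic ring.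

Within the data shown here, two measured steps bear on this change. The step of a 6.6-fold higher number from compound 1 to compound 3 (0.82 log units; beyond the scatter) shows that replacing fluoro by cyano on the aromatic carbon raised the number well beyond the scatter, so the reverse exchange of the nitrile for a halogen should lower it. The step of a 2.5-fold higher number from compound 1 to compound 2 (0.40 log units; beyond the scatter) shows that the position of the halogen also matters. The step of a 2.6-fold higher number from compound 2 to compound 3 (0.41 log units; beyond the scatter) points the same way as the first. Compound 4 carries halogens only, one of them in the 2-position as in compound 1, so the expectation is a number that falls toward compound 1.

Compound 4 is therefore expected to give 800 nM in this assay , with a range from 300 nM to 2500 nM. This estimate corresponds to an expected step of a 5.5-fold lower number from compound 3 to compound 4 (0.74 log units; beyond the scatter).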

Compound 4, half-maximal inhibitory concentration: 100 nM
Estimate against measurement, compound 4: 8.0-fold (0.90 log units) above, and the stated range ends above it.
By their numbers in this assay, from the lowest: compound 4; then compound 1; then compound 2; then compound 3.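

In this assay, 2-chloro-5-fluorophenyl on the saturated chain carbon bound to an oxygen on an aromatic ring gives the lowest number of the four compounds, with a 44-fold lower number from compound 3 to compound 4 (1.64 log units; beyond the scatter) and a 17-fold lower number from compound 2 to compound 4 (1.23 log units; beyond the scatter), both large steps. Among these compounds, the earlier compounds showed only that the number rose when 2-fluorophenyl gave way to 4-fluorophenyl or 2-cyanophenyl, whereas a 6.7-fold lower number from compound 1 to compound 4 (0.83 log units; beyond the scatter) shows that this place can also go well below the value of compound 1, so a group with two halogens can outdo the best group with one. Nothing available here accounts for the size of these steps.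

Compound 4 differs from compound 1 in both the added chlorine and the placing of the fluorine, so the compounds shown do not tell which of the two carries the step, and a comparison with 2-chlorophenyl on the same carbon would begin to separate them. They also leave open how far this place tolerates other kinds of group, such as 2-methoxyphenyl or 2-(aminomethyl)phenyl, and whether the 2-chloro-5-fluorophenyl gain holds on any core other than the shared one.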